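A Dichlorophenyl Swap on a Dopamine Receptor Agonist

This account rests on a few compounds, and the source may have more. Where it says the series, first, only, none or still open, it means among the compounds named here.

Compound 1 `CCc1cccc(NC(=O)CN2CCC(c3cccc[n+]3[O-])CC2)c1`, compound 2 `O=C(CN1CCC(c2cccc[n+]2[O-])CC1)Nc1cccc(F)c1` and compound 3 `Cc1ccc(Cl)cc1NC(=O)CN1CCC(c2cccc[n+]2[O-])CC1` share one core and differ only in the aryl group on the amide-type nitrogen. In a functional assay on HEK293 cells for agonist activity at D(4) dopamine receptor (Homo sapiens), read by FLIPR (on this read-out higher numbers stand for an effect only at larger amounts of compound and lower numbers for an effect already at smaller amounts), compound 1 gives 95 nM, compound 2 gives 160 nM and compound 3 gives 126 nM. Compound 3 thus holds the second highest of the three numbers, yet the spread among them is small: a 1.7-fold higher number from compound 1 to compound 2 (0.23 log units; within the scatter) is the widest gap of the three, and even it stays within the scatter. Compound 4 `O=C(CN1CCC(c2cccc[n+]2[O-])CC1)Nc1cc(Cl)cc(Cl)c1` is not yet measured. The change from compound 3 is 3,5-dichlorophenyl in place of 5-chloro-2-methylphenyl on an amide-type nitrogen. Among the measured compounds shown here, two measured steps touch the same place, namely a 1.3-fold higher number from compound 1 to compound 3 (0.12 log units; within the scatter) and a 1.3-fold lower number from compound 2 to compound 3 (0.10 log units; within the scatter), and neither moved beyond the scatter. Exchanging one aryl group on the amide-type nitrogen for another has so far produced no measurable shift, so the step to compound 4 is expected to be a 1.0-fold higher number from compound 3 to compound 4 (0.01 log units; within the scatter), which means no step beyond the scatter. Compound 4 is therefore estimated at 130 nM in this assay, with a range from 50 nM to 350 nM.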

Compound 4, half-maximal effective concentration: 160 nM
The estimate for compound 4 lay 1.2-fold (0.09 log units) below the measured number, and the stated range covers the measured number.
By their numbers in this assay, from the lowest: compounds 1, 3, 2 and 4 (each within the scatter of the next).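

Replacing 5-chloro-2-methylphenyl with 3,5-dichlorophenyl on the amide-type nitrogen, which exchanges the methyl for a second chlorine, keeps compound 4 within the scatter of all three earlier compounds in this assay, with a 1.3-fold higher number from compound 3 to compound 4 (0.10 log units; within the scatter) and no change at the digits printed from compound 2 to compound 4 (within the scatter) and also a 1.7-fold higher number from compound 1 to compound 4 (0.23 log units; within the scatter) as the three new steps. This position therefore now holds four different aryl groups, carrying ethyl, fluoro, chloro with methyl, or two chlorines, and this read-out cannot tell them apart. No measured evidence is available to explain why they behave alike. Every group shown here is a six-membered aromatic ring of carbon with ethyl, fluoro, chloro or methyl on it. Open, going by these compounds, is whether an amine or a carboxylic acid on that ring, or a longer chain in its place, would move the number beyond the scatter.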